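A few compounds are considered here, and "the series" means these few. Any claim that something is new, unique, unknown or untested is made for them only; others in the source may bear on it.

Compounds measured so far:
compound 1, `O=[N+]([O-])c1ccc(CN2CCC(n3cc(CC(OCc4cc(-c5ccccc5)no4)c4ccc(Br)cc4)nn3)CC2)cc1`: > 25000 nM
compound 2, `N#Cc1cccc(-c2cc(COC(Cc3cn(C4CCN(Cc5ccc([N+](=O)[O-])cc5)CC4)nn3)c3ccc(Br)cc3)on2)c1`: > 25000 nM

In a functional assay on PC-3 cells (Homo sapiens) for cytotoxicity, with a stated time of 48 h (a higher number here means a weaker inhibitor, a lower number a stronger inhibitor), compound 1 gives > 25000 nM, which is a limit of the assay and not a number. Compound 2 likewise gives > 25000 nM, again only a limit. The step that the two limits leave unreadable from compound 1 to compound 2 cannot be read because the limit of > 25000 nM in this assay, at which 2 of the 2 values shown sit, marks both values. Compound 3, `O=[N+]([O-])c1ccc(CN2CCC(n3cc(CC(OCc4cc(-c5ccccc5F)no4)c4ccc(Br)cc4)nn3)CC2)cc1`, differs from compound 2 by 2-fluorophenyl in place of 3-cyanophenyl on an aromatic carbon. No readable measured step bears on this change, so neither a direction nor a size can be drawn from the two measured compounds. Compound 3 is therefore expected to give 30000 nM, with a range from 8000 nM to 120000 nM. The expected step from compound 2 is a step that the limit leaves unreadable from compound 2 to compound 3, carrying little confidence.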

Compound 3, half-maximal inhibitory concentration: 6000 nM
The estimate for compound 3 lay 5.0-fold (0.70 log units) above the measured number; measured number outside the range, below it.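

Placing 2-fluorophenyl instead of 3-cyanophenyl on this aromatic carbon of the five-membered ring gives an at least 4.1-fold lower number from compound 2 to compound 3 (0.61 log units; beyond the scatter) in this assay. Fluoro in place of hydrogen gives an at least 4.1-fold lower number from compound 1 to compound 3 (0.61 log units; beyond the scatter), so this single replacement is enough to bring a measurable value in this assay. Going by these compounds, the step from compound 1 to compound 2 still cannot be read, and the true sizes of both new steps stay open, because compound 1 and compound 2 rest on a limit: the limit of > 25000 nM in this assay, at which 2 of the 3 values shown sit. Whether a methoxy group or an amine on that phenyl ring would lower the number further remains open.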